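Three Close Values and a Cyanophenyl Swap

A few compounds are considered here, and "the series" means these few. Any claim that something is new, unique, unknown or untested is made for them only; others in the source may bear on it.

Compound 1, `CCCCc1cnc(C(CCCC)Cc2ccc(-c3ccccc3C(=O)O)cc2)[nH]1`, gives 2660 nM in an in vitro functional assay on cells for agonist activity at Bombesin receptor subtype-3 (Homo sapiens), read by luminescence and calcium flux; on this read-out higher numbers stand for an effect only at larger amounts of compound and lower numbers for an effect already at smaller amounts.
Compound 2, `CCCCc1cnc(C(CC)Cc2ccc(-c3ccccc3C(=O)O)cc2)[nH]1`, gives 2720 nM.
Compound 3, `CCCCc1cnc(CCc2ccc(-c3ccccc3C(=O)O)cc2)[nH]1`, gives 2710 nM.

On these numbers compound 3 sits second highest of the three, within the scatter of both: the steps of a 1.0-fold higher number from compound 1 to compound 3 (0.01 log units; within the scatter) and a 1.0-fold lower number from compound 2 to compound 3 (0.00 log units; within the scatter) show that removing the chain on one saturated carbon changes nothing measurable. Compound 4, `N#Cc1cccc(Cc2cnc(CCc3ccc(-c4ccccc4C(=O)O)cc3)[nH]2)c1`, differs from compound 3 elsewhere: 3-cyanophenyl in place of propyl on a saturated chain carbon bound to an aromatic carbon. Within the data shown here, no measured step touches this part of the molecule, so the measured steps give no direct guide; they only show that the remaining shared core tolerates small changes in its chains without a shift. The expectation is therefore a step of about a 1.1-fold lower number from compound 3 to compound 4 (0.04 log units; within the scatter), with a wide range. For compound 4 the estimated value is 2500 nM, between 500 nM and 12000 nM.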

Compound 4, half-maximal effective concentration: 812 nM
The estimate for compound 4 lay 3.1-fold (0.49 log units) above the measured number, and the stated range covers the measured number.
By their numbers in this assay, from the lowest: compound 4; then compounds 1, 3 and 2 (each within the scatter of the next).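

Among these compounds, the earlier steps all lay within the scatter, but 3-cyanophenyl in place of propyl on a saturated chain carbon bound to an aromatic carbon gives, in this assay, a 3.3-fold lower number from compound 3 to compound 4 (0.52 log units; beyond the scatter) as the first step beyond it, though a modest one. This position therefore responds to change, unlike the chain carbons varied among compounds 1, 2 and 3. No evidence here bears on why the number falls.

The nitrile and the aromatic ring enter together, so their shares stay unseparated. A plain phenyl in the same place would show whether the ring alone carries the step.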